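Swapping the Hydroxyl Side Chain on the Shared Core

The source may report more compounds than this note shows. Statements on the series, on what has been measured and on what is new or still open speak of the compounds shown alone.

Compound 1 `CC(C)(CO)CNC(=O)c1cc2cc(C#N)ccc2n1Cc1cccc(OC(F)(F)F)c1`: < 6 mL.min-1.g-1
Compound 2 `CCCOc1cccc(Cn2c(C(=O)NCC(C)(C)CO)cc3cc(C#N)ccc32)c1`: 13 mL.min-1.g-1

In an in vitro ADME assay on microsomes from Gut (Homo sapiens) for metabolic stability, using NADPH (on this read-out higher numbers stand for fast clearance and lower numbers for slow clearance), compound 1 gives < 6 mL.min-1.g-1, which is a limit of the assay and not a number; compound 1 sits at the limit of < 6 mL.min-1.g-1 in this assay, at which 1 of the 2 values shown sits. Compound 2 gives 13 mL.min-1.g-1 in this assay. Among the compounds with values here, the one measured step, an at least 2.1-fold higher number from compound 1 to compound 2 (0.33 log units; beyond the scatter), concerns the group on the oxygen on the aromatic ring. Compound 3 `N#Cc1ccc2c(c1)cc(C(=O)NCCC1(O)CCC1)n2Cc1cccc(OC(F)(F)F)c1` has not been measured; it differs from compound 1 in a different place, ((1-hydroxycyclobutyl)methyl in place of 1-(hydroxymethyl)-1-methylethyl on a saturated chain carbon bound to an amide-type nitrogen). Within the data shown here, no measured step touches this part of the molecule, so the available numbers say nothing about how large a change to expect there. The expectation is therefore that compound 3 stays close to where compound 1 sits, an estimated step of a number no lower from compound 1 to compound 3 (the limit leaves the size open). For compound 3 the estimate in this assay is 6 mL.min-1.g-1, with a range from 3 mL.min-1.g-1 to 13 mL.min-1.g-1.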

Compound 3, intrinsic clearance in microsomes: < 6 mL.min-1.g-1
Compound 3: only a limit was reported; the forecaster's own chance of this, stated with the estimate: 50%; the middle value lies on the limit itself.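

Compound 3, like compound 1, is reported in this assay only as a limit and not a number, so no step between the two can be read: the limit of < 6 mL.min-1.g-1 in this assay, at which 2 of the 3 values shown sit.

The compounds shown leave open whether (1-hydroxycyclobutyl)methyl in place of 1-(hydroxymethyl)-1-methylethyl changes clearance at all, and by how much.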